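This account rests on a few compounds, and the source may have more. Where it says the series, first, only, none or still open, it means among the compounds named here.

Three compounds sharing one amide core have been followed in an ADME assay on the whole organism (Mus musculus, strain CD1), read by LC-MS, using cassette dosing, with a stated time of 24 h, at a dose of 0.4 mg/kg by the intravenous route; a lower number here means that the compound disappears faster, a higher number that the compound lasts longer. Compound 1 `Cc1cn(-c2cc(NC(=O)c3ccc(C)c(Nc4nccc(-c5ccccc5)n4)c3)cc(N3CCNCC3)c2)cn1` gives 1.19 h in this assay. Compound 2 `Cc1cn(-c2cc(NC(=O)c3ccc(C)c(Oc4ccccc4)c3)cc(C(F)(F)F)c2)cn1` gives 2.27 h. Compound 3 `Cc1cn(-c2cc(NC(=O)c3ccc(C)c(Oc4ccccc4)c3)cc(N3CCN(C)CC3)c2)cn1` gives 8.98 h, the highest of the three numbers; compound 2 comes nearest to it, and compound 1 lies furthest from it. Among the measured compounds shown here, the only step between two compounds that differ in a single place, a 4.0-fold higher number from compound 2 to compound 3 (0.60 log units; beyond the scatter), concerns a group that compound 3 keeps unchanged in what follows.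

Compound 4 `Cc1cn(-c2cc(NC(=O)c3ccc(C)c(C(=O)c4cccc(C#N)c4)c3)cc(N3CCN(C)CC3)c2)cn1` has not yet been measured. It differs from compound 3 in one place: (3-cyanophenyl)carbonyl in place of phenoxy on an aromatic carbon. For the measured compounds named here, no measured pair shows this exchange or anything close to it. The step from compound 2 to compound 3 touches a different part of the core, so it offers no guide to the direction of this one. Compound 1 differs from compound 3 in more than one place and cannot be read as a single step either. The expectation therefore rests on the spread of the three measured numbers rather than on a matching step. Compound 4 is expected to give about 6 h in this assay, within a range from 2.5 h to 15 h. That estimate means an expected step of a 1.5-fold lower number from compound 3 to compound 4 (0.18 log units; within the scatter), a change that may well stay within the usual scatter.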

Compound 4, mean residence time: 0.96 h
The estimate for compound 4 lay 6.3-fold (0.80 log units) above the measured number; the whole stated range lies above it.
By their numbers in this assay, from the lowest: compounds 4, 1 and 2 (each within the scatter of the next, the first and the last beyond it); then compound 3.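

Among the compounds shown here, replacing phenoxy with (3-cyanophenyl)carbonyl on an aromatic carbon ortho to a methyl group gives a 9.4-fold lower number from compound 3 to compound 4 (0.97 log units; beyond the scatter) in this assay and shows that this position, untouched by the only earlier single-place step, can strongly change how long a compound lasts. The 4-methylpiperazin-1-yl group stays in place across this exchange, so the rise seen earlier with that group, a 4.0-fold higher number from compound 2 to compound 3 (0.60 log units; beyond the scatter) with phenoxy present, does not guarantee a long-lasting compound once phenoxy has gone. Nothing measured here gives a reason for the drop.

This exchange alters two things at once, the carbonyl taking the place of the ring-linking oxygen and a nitrile appearing on the aromatic ring, so the compounds shown cannot say which of the two matters, or whether both are needed. A plain phenylcarbonyl group without the nitrile, or a 3-cyanophenoxy group that keeps the oxygen, would separate these two changes, and pairing either group with trifluoromethyl in place of 4-methylpiperazin-1-yl would test whether the outcome depends on that other site.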